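Methoxy in Place of Fluoro, Starting from a Limit

The source may report more compounds than this note shows. Statements on the series, on what has been measured and on what is new or still open speak of the compounds shown alone.

Among the measured compounds shown here, compound 2 `CCC(COc1cccc(F)c1)OC(=O)NCc1ccccc1` is one of two compounds measured in an assay for inhibition of zeta-carotene desaturase, chloroplastic/chromoplastic (Capsicum annuum), using a Dixon plot, with a stated time of 8 h; a lower number here means a stronger inhibitor, a higher number a weaker inhibitor. In this assay compound 2 gives only the limit > 100000 nM, not a number. Compound 1 `CCC(COc1ccccc1Cl)OC(=O)NCc1ccccc1` likewise gives only the limit > 100000 nM in this assay. The step in this assay is a step that the two limits leave unreadable from compound 1 to compound 2, so it offers no readable size or direction. Both measured values sit at the limit of > 100000 nM in this assay, at which 2 of the 2 values shown sit.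

Compound 3 `CCC(COc1cccc(OC)c1)OC(=O)NCc1ccccc1` has not yet been measured in this assay; it differs from compound 2 by methoxy in place of fluoro on an aromatic carbon. For the measured compounds named here, no measured step covers this change, and the single available step is unreadable, so no direction can be drawn from it. Compound 3 is therefore expected to give a value near 150000 nM in this assay, within a range of 30000 nM to 1000000 nM, most probably again reported only as a limit. The estimated step is a step that the limit leaves unreadable from compound 2 to compound 3.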

Compound 3, half-maximal inhibitory concentration: > 100000 nM
Compound 3 ended at the assay's limit (the forecaster's own chance of this, stated with the estimate: 85%); the middle value is on the limit's open side.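

Compound 1, compound 2 and compound 3 all give only a limit, not a number, so none of the steps among them can be read in this assay: the limit of > 100000 nM in this assay, at which 3 of the 3 values shown sit.

The compounds shown leave open how strongly any of them inhibits, and whether methoxy in place of fluoro changes that at all.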